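Substituents on the benzyl ring: the step to compound 4

A few compounds are considered here, and "the series" means these few. Any claim that something is new, unique, unknown or untested is made for them only; others in the source may bear on it.

Compound 1 `COc1cccc(OC)c1OCCNCCOc1ccccc1OCc1ccccc1` carries the plain benzyl group. Within the data shown here, in an assay on CHO cells for displacement of a labelled ligand from Alpha-1B adrenergic receptor (Homo sapiens) (on this read-out lower numbers stand for stronger inhibition and higher numbers for weaker inhibition), compound 1 gives 0.537 nM, the second highest of the three numbers measured so far; compound 3 `COc1cccc(OC)c1OCCNCCOc1ccccc1OCc1ccc([N+](=O)[O-])cc1` gives 0.398 nM and compound 2 `COc1cccc(OC)c1OCCNCCOc1ccccc1OCc1ccccc1C` gives 0.794 nM, and both of these sit within the scatter of compound 1, so no order among the three can be read.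

Compound 4 `COc1ccccc1COc1ccccc1OCCNCCOc1c(OC)cccc1OC` differs from compound 1 by methoxy in place of hydrogen on an aromatic carbon, phenyl to 2-methoxyphenyl, the new group ortho to a large group. The measured steps on this ring are a 1.5-fold higher number from compound 1 to compound 2 (0.17 log units; within the scatter) and a 1.3-fold lower number from compound 1 to compound 3 (0.13 log units; within the scatter); the step of a 2.0-fold lower number from compound 2 to compound 3 (0.30 log units; within the scatter) likewise stays within the scatter. Neither methyl nor nitro on this ring moved this assay beyond the usual spread, so methoxy is not expected to do so either. For compound 4 the estimate in this assay is 0.6 nM, within 0.3 nM to 1.2 nM. The expected step is therefore a 1.1-fold higher number from compound 1 to compound 4 (0.05 log units; within the scatter), nothing beyond the scatter.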

Compound 4, inhibition constant: 6.31 nM
Compound 4: middle estimate off by 11-fold (1.02 log units), on the low side, and the stated range ends below it.
By their numbers in this assay, from the lowest: compounds 3, 1 and 2 (each within the scatter of the next); then compound 4.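

In this assay, among these compounds, the benzyl ring does respond to substitution: methoxy in place of hydrogen, ortho to a large group, gives a 12-fold higher number from compound 1 to compound 4 (1.07 log units; beyond the scatter), the first step on this ring beyond the scatter. Compound 4 also stands apart from the two other substituted compounds, with a 7.9-fold higher number from compound 2 to compound 4 (0.90 log units; beyond the scatter) and a 16-fold higher number from compound 3 to compound 4 (1.20 log units; beyond the scatter), while 2-methylphenyl and 4-nitrophenyl both stay within the scatter of the plain phenyl of compound 1. No measurement at hand offers an explanation for this weaker inhibition.

On these data alone, it remains open whether the step follows methoxy as such or its place on the ring, which methoxy elsewhere on the ring would separate. Also open, as far as these compounds go, is whether ethoxy or hydroxyl at the same place gives a step of similar size.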